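Saturating the chain of a vanilloid amide for rat TRPV2

The source may hold more compounds than are shown below. What is called first, only, known or untested is meant among the compounds shown, and "the series" means these compounds.

Measured so far:
- compound 1, `CCCCCCCC/C=C\CCCCCCCCCCCC(=O)NCc1ccc(O)c(OC)c1`, 1500 nM
- compound 2, `CCCCCCCC/C=C\CCCCCCCCSCCC(=O)NCc1ccc(O)c(OC)c1`, "not determined" (no result reported)
- compound 3, `CCCCCCC(=O)CC(O)CCCCCCCCC(=O)NCc1ccc(O)c(OC)c1`, > 10000 nM

All three compounds share a core, shown beside compound 1, carrying a long fatty chain. They were tested in an assay on HEK293 cells for antagonist activity at transient receptor potential cation channel subfamily V member 2 (Rattus norvegicus), read by fluorescence and calcium flux, with a stated time of 5 min; a higher number here means a weaker inhibitor, a lower number a stronger inhibitor. For the measured compounds named here, compound 1 gives 1500 nM, and it is the only compound with a single number. Compound 2 has no result recorded, "not determined" (no result reported). Compound 3 reaches only the limit of this assay, (the limit of > 10000 nM in this assay, at which 1 of the 3 values shown sits), and so gives no number.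

The compound still to be measured is compound 4, `CCCCCCCCCCCCCCCCCCCC(=O)NCc1ccc(O)c(OC)c1`. It differs from compound 1 in one place: octyl in place of dec-1-en-1-yl on a saturated chain carbon, ten or more bonds along the chain from a carbonyl carbon. The chain keeps its length, but the double bond is gone.

Going by the values given here, no step between measured compounds exists here, so the direction of this change must be guessed from compound 1 alone. Saturating the chain is expected to weaken inhibition somewhat, a step from compound 1 of a 2.3-fold higher number from compound 1 to compound 4 (0.37 log units; beyond the scatter), which lies only a little beyond the scatter. Compound 4 is therefore estimated at 3500 nM, with a likely range from 900 nM to 14000 nM.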

Compound 4, half-maximal inhibitory concentration: > 10000 nM
Compound 4 gave a limit, no number; the forecaster's own chance of this, stated with the estimate: 25%; middle value at least 2.8-fold (0.45 log units) away from the limit.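

In this assay, the chain of compound 1 does not tolerate this change: putting octyl in place of dec-1-en-1-yl on a saturated chain carbon gives an at least 6.6-fold higher number from compound 1 to compound 4 (0.82 log units; beyond the scatter). For the compounds shown here, this is the first comparison here between two compounds that differ in one place, and it shows that a part of the chain far from the carbonyl carbon matters for inhibition of the channel. The entry for compound 4 is a limit and not a number, so the full size of the step stays unknown: the limit of > 10000 nM in this assay, at which 2 of the 4 values shown sit.

The swap removes the double bond and also leaves octyl with fewer carbons than dec-1-en-1-yl, so this single step cannot say which of the two differences accounts for the loss. A saturated decyl group in the same place would keep the carbon count and lose only the double bond, while a triple bond at that point of the chain would show whether the double bond itself can be replaced.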